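Swapping the Aryl Hydrazone Terminus: Bromophenyl to Hydroxyphenyl

The source may hold more compounds than are shown below. What is called first, only, known or untested is meant among the compounds shown, and "the series" means these compounds.

Three compounds share one core and differ only in the aryl group on the hydrazone carbon. In a functional assay on HT-29 cells (Homo sapiens) for cytotoxicity, read by MTT assay, with a stated time of 72 h (a lower number here means a stronger inhibitor, a higher number a weaker inhibitor), compound 1 `CN(C)CCn1cnnc1-c1cc(Oc2ccc(NC(=O)N/N=C/c3c[nH]c4ccccc34)cc2F)ccn1` gives 1300 nM, compound 2 `COc1ccc(/C=N/NC(=O)Nc2ccc(Oc3ccnc(-c4nncn4CCN(C)C)c3)c(F)c2)c(OC)c1` gives 1780 nM, and compound 3 `CN(C)CCn1cnnc1-c1cc(Oc2ccc(NC(=O)N/N=C/c3cccc(Br)c3)cc2F)ccn1` gives 380 nM. Compound 3 holds the lowest number of the three: the step of a 3.4-fold lower number from compound 1 to compound 3 (0.53 log units; beyond the scatter) and the step of a 4.7-fold lower number from compound 2 to compound 3 (0.67 log units; beyond the scatter) both lie beyond the scatter, whereas the step of a 1.4-fold higher number from compound 1 to compound 2 (0.14 log units; within the scatter) does not.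

Compound 4 `CN(C)CCn1cnnc1-c1cc(Oc2ccc(NC(=O)N/N=C/c3ccc(O)cc3)cc2F)ccn1` is the next member. Compared with compound 3 it carries 4-hydroxyphenyl in place of 3-bromophenyl on a carbon with a double bond to nitrogen. Among the compounds with values here, none of the measured steps covers this exact exchange. What they do show is that the two aryl groups other than 3-bromophenyl, namely 1H-indol-3-yl in compound 1 and 2,4-dimethoxyphenyl in compound 2, both gave higher numbers than compound 3 in this assay, by the modest steps already quoted. On that basis the move away from 3-bromophenyl to 4-hydroxyphenyl is expected to raise the number by a modest amount, a 2.4-fold higher number from compound 3 to compound 4 (0.37 log units; beyond the scatter), though with wide uncertainty. Compound 4 is therefore estimated at 900 nM in this assay, within a range from 300 nM to 2800 nM.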

Compound 4, half-maximal inhibitory concentration: 1920 nM
Estimate against measurement, compound 4: 2.1-fold (0.33 log units) below; measured number inside the range.
By their numbers in this assay, from the lowest: compound 3; then compounds 1, 2 and 4 (each within the scatter of the next).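

In this assay, a 5.1-fold higher number from compound 3 to compound 4 (0.70 log units; beyond the scatter) shows that a hydroxyl-bearing aryl group on this carbon does not keep the low number of compound 3, and that this exchange, in which bromine leaves, oxygen enters and one hydrogen-bond donor and one acceptor are added by count, lies beyond the scatter. With a 1.1-fold higher number from compound 2 to compound 4 (0.03 log units; within the scatter) and a 1.5-fold higher number from compound 1 to compound 4 (0.17 log units; within the scatter), both within the scatter, compound 4 joins compound 1 and compound 2 in one group that cannot be told apart here, so that among these four aryl groups 3-bromophenyl alone stands apart from all the others, while 4-hydroxyphenyl, 2,4-dimethoxyphenyl and 1H-indol-3-yl give no order among themselves. No available evidence bears on what lies behind this separation.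

The step from compound 3 to compound 4 changes both the substituent and where it sits on the ring, so the compounds shown cannot say which of the two matters; 4-bromophenyl and 3-hydroxyphenyl would separate them. Within the data shown here, whether the result is particular to bromine also stays open, as no compound here carries 3-chlorophenyl or 3-aminophenyl on this carbon.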